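The source may hold more compounds than are shown below. What is called first, only, known or untested is meant among the compounds shown, and "the series" means these compounds.

Measured so far in an assay on isolated protein for inhibition of proto-oncogene tyrosine-protein kinase receptor Ret (Homo sapiens), read by 33P incorporation, with stated times of 15 min and 40 min; a higher number here means a weaker inhibitor, a lower number a stronger inhibitor:
Compound 1, `O=C(Nc1ccc(Nc2ncnc3c2OCCN3)cc1)Nc1cc(Cl)cc(Cl)c1`: 865 nM.
Compound 2, `CC(C)(C)c1cc(NC(=O)Nc2ccc(Nc3ncnc4c3OCCN4)cc2)no1`: 10 nM.
Compound 3, `O=C(Nc1ccc(Nc2ncnc3c2OCCN3)cc1)Nc1cccs1`: > 10000 nM, which is a limit of the assay and not a number.

Compound 2 gives the lowest of the two numbers shown; the nearest is compound 1, separated from it by an 87-fold lower number from compound 1 to compound 2 (1.94 log units; beyond the scatter). The third value is only a limit: compound 3 sits at the limit of > 10000 nM in this assay, at which 1 of the 3 values shown sits. Compound 4, `CC(C)(C)c1cc(NC(=O)Nc2ccc(Nc3ncnc4c3OCCN4)c(O)c2)no1`, has not yet been measured. It differs from compound 2 in one place: hydroxy in place of hydrogen on an aromatic carbon, the place being an aromatic carbon of a six-membered aromatic ring of carbon only, ortho to a large group and meta to a large group. The measured steps all exchange the group on an amide-type nitrogen: an 87-fold lower number from compound 1 to compound 2 (1.94 log units; beyond the scatter), an at least 11-fold higher number from compound 1 to compound 3 (1.06 log units; beyond the scatter) and an at least 1000-fold higher number from compound 2 to compound 3 (3.00 log units; beyond the scatter) were all large, but none of them changes the place altered here. Among the measured compounds shown here, no measured step therefore speaks to this change, and only a step within the scatter, or a small one, is expected in this assay. Compound 4 is estimated at 15 nM, between 4 nM and 60 nM, which is expected to mean a step of a 1.5-fold higher number from compound 2 to compound 4 (0.18 log units; within the scatter).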

Compound 4, half-maximal inhibitory concentration: 25 nM
The estimate for compound 4 lay 1.7-fold (0.22 log units) below the measured number; measured number inside the range.
By their numbers in this assay, from the lowest: compound 2; then compound 4; then compound 1. At a limit, above all of these: compound 3.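

In this assay, hydroxy on this aromatic carbon, ortho to a large group and meta to a large group, gives a 2.5-fold higher number from compound 2 to compound 4 (0.40 log units; beyond the scatter). This is the first change shown on this six-membered ring rather than on the group at the amide-type nitrogen, and it shows that the place accepts a hydroxy at a modest cost, whereas every exchange at that nitrogen shown so far gave a large step. Nothing measured here gives a reason for this step.

On these data alone, whether a methoxy, a fluorine or an amine on the same carbon would give a smaller or a larger step remains open. Also open, as far as these compounds go, is whether hydroxy would have a similar effect on the other carbons of this ring, or alongside the 3,5-dichlorophenyl group of compound 1.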